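The compounds below may be only part of what the source reports. "The series", "measured", "known", "first", "only" and "open" are said of these compounds alone.

Measured in an ADME assay on MIA PaCa-2 cells (Homo sapiens) for cytotoxicity, read by MTT assay, with a stated time of 72 h; on this read-out higher numbers stand for weaker inhibition and lower numbers for stronger inhibition:
Compound 1 `COc1ccc(C2=C(c3cc(OC)c(OC)c(OC)c3)C(=O)C(OC(C)=O)C2)cc1OC(C)C`: > 100 ug/mL, a limit.
Compound 2 `COc1ccc(C2=C(c3cc(OC)c(OC)c(OC)c3)C(=O)C(O)C2)cc1Cl`: > 100 ug/mL, a limit.
Compound 3 `COc1ccc(C2=C(c3cc(OC)c(OC)c(OC)c3)C(=O)C(OC(C)=O)C2)cc1Cl`: 24 ug/mL.

Compound 2 has no numerical value, only a limit, and the one other limit among these compounds belongs to compound 1. Compound 4 `COc1ccc(C2=C(c3cc(OC)c(OC)c(OC)c3)C(=O)C(O)C2)cc1OC(C)C` is compound 2 with isopropoxy in place of chloro on an aromatic carbon.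

For the measured compounds named here, two measured steps bear on this change. The first is the same swap read in reverse, on compounds that carry an acetyl on the oxygen: an at least 4.1-fold lower number from compound 1 to compound 3 (0.61 log units; beyond the scatter), with chloro in place of isopropoxy. This step lies beyond the scatter. It suggests that isopropoxy would, if anything, move the number up rather than down. The second step, an at least 4.1-fold lower number from compound 2 to compound 3 (0.61 log units; beyond the scatter), comes from acetyl in place of hydrogen on that oxygen, and compound 4 keeps the hydrogen. Compound 4 therefore lacks both features present in compound 3, and any reading is bounded by the limit of > 100 ug/mL in this assay, at which 2 of the 3 values shown sit.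

No step beyond the scatter is expected, and a report of only a limit is the likely outcome. The expected change is a step that the limit leaves unreadable from compound 2 to compound 4. For compound 4 the estimated value is 120 ug/mL, with an expected range of 50 ug/mL to 300 ug/mL.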

Compound 4, half-maximal inhibitory concentration: > 100 ug/mL
Compound 4: no number, only a limit; the forecaster's own chance of this, stated with the estimate: 80%; the middle value does not contradict the limit.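

In this assay compound 4 gives > 100 ug/mL, which is a limit. No step from compound 1 or compound 2 to compound 4 can be read, because those compounds also carry only limits: the limit of > 100 ug/mL in this assay, at which 3 of the 4 values shown sit.

The compounds shown leave open whether isopropoxy in place of chloro changes the number at all when that oxygen carries hydrogen.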